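Chloro substitution on two amide aryl groups

The compounds below may be only part of what the source reports. "The series", "measured", "known", "first", "only" and "open" are said of these compounds alone.

Four amides sharing one dithiol-bearing chain are compared. Compound 1 `O=C(CCCCC(S)CCS)Nc1ccccc1` carries a phenyl on the amide nitrogen; compound 2 `O=C(CCCCC(S)CCS)Nc1ccc(Cl)cc1` adds a chloro to that ring; compound 3 `O=C(CCCCC(S)CCS)Nc1ccccn1` carries a pyridin-2-yl instead of the phenyl; compound 4 `O=C(CCCCC(S)CCS)Nc1ccc(Cl)cn1` is the pyridine analogue with the chloro added, not yet measured.

In a functional assay on KB cells (Homo sapiens) for inhibition, read by MTT assay, with a stated time of 24 h, tested at 100 ug/mL (a higher number here means more inhibition of growth at the concentration tested, a lower number less inhibition of growth), compound 1 gives 15.8%, compound 2 gives 44.1% and compound 3 gives 18.5%. The change from compound 1 to compound 2 is chloro in place of hydrogen on an aromatic carbon and brings a number 28.3 percentage points higher from compound 1 to compound 2 (beyond the scatter). The cores differ by pyridin-2-yl in place of phenyl on an amide-type nitrogen, which gives a number 2.7 percentage points higher from compound 1 to compound 3 (within the scatter), so the two parent amides sit within the scatter of each other.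

The change from compound 3 to compound 4 is chloro in place of hydrogen on an aromatic carbon. It is the same kind of change as that from compound 1 to compound 2: in both a chloro replaces a hydrogen on an aromatic carbon para to a large group, but in compound 4 the ring is a six-membered aromatic ring with one nitrogen and the chloro sits two atoms from the ring nitrogen, whereas in compound 2 the ring is of carbon only.

Going by the values given here, with the parents alike and only one precedent, a step of roughly the same size is expected, tempered for the different ring; from compound 3 to compound 4 in this assay a step of about a number 23.5 percentage points higher from compound 3 to compound 4 (beyond the scatter) is estimated, resting on a number 28.3 percentage points higher from compound 1 to compound 2 (beyond the scatter). Compound 4 is expected to give about 42%, likely between 25% and 60%.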

Compound 4, percent growth inhibition at one concentration: 76.6%
Beside the measured number, compound 4's estimate is 34.6 percentage points below it, and the stated range ends below it.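

In this assay, chloro in place of hydrogen on an aromatic carbon gives a higher number on both cores, and on the pyridin-2-yl core it gives a number 58.1 percentage points higher from compound 3 to compound 4 (beyond the scatter). This does not show why the two steps differ: two matched pairs, read at one concentration and one time, give no cause, and they set no rule for a chloro at another ring position or on any other ring. The direction of the change carries from the core of compound 1 to the core of compound 3 in these two pairs, but its size does not, so a step measured on one core is a poor guide to its size on the other: the same change on two cores in this assay, a number 28.3 percentage points higher (beyond the scatter) from compound 1 to compound 2 and a number 58.1 percentage points higher (beyond the scatter) from compound 3 to compound 4, 29.8 percentage points apart, beyond the scatter of two such steps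

Open, as far as these compounds go, is whether a fluoro, a bromo or a methoxy in place of the chloro, on the same aromatic carbon para to a large group, would also give a larger step on the pyridin-2-yl core than on the phenyl core. Also open, from the compounds shown here alone, is whether the difference between the two steps would persist with a longer chain in place of the shared dithiol-bearing chain, or with an amine or a carboxylic acid on that chain.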